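The source may hold more compounds than are shown below. What is called first, only, known or untested is meant among the compounds shown, and "the series" means these compounds.

Compound 2 `O=C1c2ccccc2C(=O)N1CNc1ccc(O)cc1` stands highest of the two compounds measured in an assay on isolated protein for inhibition of ribosomal protein S6 kinase alpha-2 (Homo sapiens), read by fluorescence, with a stated time of 20 min, tested at 10 uM (on this read-out higher numbers stand for more inhibition at the one concentration tested (going by the name of the read-out) and lower numbers for less inhibition), where compound 2 gives 101%. For the measured compounds named here, its only neighbour, compound 1 `O=C1c2ccccc2C(=O)N1CNc1ccc(OC(F)(F)F)cc1`, gives 28.1% in this assay, and the step of a number 72.9 percentage points higher from compound 1 to compound 2 (beyond the scatter) is the single measured step that bears on the change now considered. Compound 3 `CCOc1ccc(NCN2C(=O)c3ccccc3C2=O)cc1` differs from compound 2 by ethyl in place of hydrogen on an oxygen on an aromatic ring. Since capping the oxygen with trifluoromethyl cost so much in compound 1, an ethyl cap is expected to cost as well, though less; the expected step of a number 46 percentage points lower from compound 2 to compound 3 (beyond the scatter) is therefore downward. Compound 3 is estimated at 55%, in the range 20% to 95%.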

Compound 3, a percentage reported as inhibition, at one concentration (the size of the read-out at that concentration, not a potency): 100%
For compound 3 the middle estimate is 45 percentage points below the measured one, and the stated range ends below it.
By their numbers in this assay, from the lowest: compound 1; then compounds 3 and 2 (each within the scatter of the next).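

In this assay, the step of a number 1 percentage points lower from compound 2 to compound 3 (within the scatter) shows that the number is level with an ethyl cap on the oxygen in place of the free hydroxy on this aromatic ring. The step of a number 71.9 percentage points higher from compound 1 to compound 3 (beyond the scatter) then ties the low number of compound 1 to trifluoromethyl itself, not to capping the oxygen as such. Nothing available here explains why these two caps differ so widely. Still open, on these data alone, is whether a longer chain such as butoxy would match ethoxy, and whether an amine in place of the hydroxy would hold up.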